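Bromo to nitro on the outer phenoxy ring

This account rests on a few compounds, and the source may have more. Where it says the series, first, only, none or still open, it means among the compounds named here.

Measured so far in a physicochemical assay for lipophilicity, in phosphate buffer, measured as octanol-water partition; a higher number here means a more lipophilic compound, a lower number a more polar compound:
compound 1 `CCCc1nc2ccccc2c(=O)n1/N=C/c1ccc(Oc2ccc(Br)cc2)cc1`: 5.88
compound 2 `O=c1c2ccccc2nc(-c2ccccc2)n1/N=C/c1ccc(Oc2ccc(Br)cc2)cc1`: 6.39
compound 3 `Cc1cc(Oc2ccc(/C=N/n3c(C)nc4ccccc4c3=O)cc2)ccc1Cl`: 4.41

Compound 1 stands second highest of the three numbers in this assay. Its nearest neighbour is compound 2, which lies above it by a number 0.51 log units higher from compound 1 to compound 2 (beyond the scatter); the change there is phenyl in place of propyl on an aromatic carbon. Within the data shown here, compound 3 lies furthest away and sits well below compound 1; no single-point step links these two.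

Compound 4 `CCCc1nc2ccccc2c(=O)n1/N=C/c1ccc(Oc2ccc([N+](=O)[O-])cc2)cc1` is not yet measured. Relative to compound 1 the difference is nitro in place of bromo on an aromatic carbon. Among the measured compounds shown here, none of the measured steps touches this position: the only step available, from compound 1 to compound 2, alters the substituent on the shared core, not the group on the outer phenoxy ring, and compound 3 differs from compound 1 in several places at once. The expectation for compound 4 therefore rests on the structural change alone. Compound 4 is expected to come out lower than compound 1 by a step of a number 1.08 log units lower from compound 1 to compound 4 (beyond the scatter), beyond the scatter. The estimate for compound 4 in this assay is 4.8, with a range from 4.2 to 5.5.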

Compound 4, partition coefficient: 5.18
Estimate against measurement, compound 4: 0.38 log units below; the measured number falls inside the stated range.
By their numbers in this assay, from the lowest: compound 3; then compound 4; then compound 1; then compound 2.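

In this assay the outer phenoxy ring now has a measured step of its own: nitro in place of bromo, para to a large group, gives a number 0.70 log units lower from compound 1 to compound 4 (beyond the scatter) with propyl held constant on the shared core. Among these compounds, the only earlier step changed the substituent on the shared core, so this is the first reading of a change at this position. The evidence at hand gives no measured cause for this step, which stands as an observation on a single pair.

On these data alone, whether the same exchange gives a similar step with phenyl on the shared core, as in compound 2, remains open. Also open, as far as these compounds go, is how an amine or a carboxylic acid at this position would read in this assay alongside bromo and nitro.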